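The source may report more compounds than this note shows. Statements on the series, on what has been measured and on what is new or still open speak of the compounds shown alone.

Compound 1 `CSc1nc(NCCCCCO)c2ccccc2n1`: 99400 nM
Compound 2 `CSc1nc(NCCCc2ccccc2)c2ccccc2n1`: > 100000 nM, a limit of the assay rather than a number.
Compound 3 `[SeH]c1nc([SeH])c2cccnc2n1`: "not determined" (no result reported)

For the measured compounds named here, in an ADME assay on BEAS-2B cells (Homo sapiens) for cytotoxicity, read by MTT assay, with a stated time of 72 h (a higher number here means a weaker inhibitor of growth, a lower number a stronger inhibitor of growth), compound 1 gives 99400 nM and stands as the only single number among the three entries. Compound 2 contributes only a limit, and compound 3 has no result. The compound to be judged, compound 4 `CSc1nc(Nc2ccccc2)c2ccccc2n1`, differs from compound 1 by phenyl in place of 5-hydroxypentyl on a nitrogen on an aromatic ring. Going by the values given here, one measured step bears on this: a number no lower from compound 1 to compound 2 (the limit leaves the size open), in which a phenyl also replaces a hydroxyl-bearing chain on the same side of the shared core. Its size cannot be read, because the limit of > 100000 nM in this assay, at which 1 of the 3 values shown sits, caps the second value. A phenyl entering in place of a hydroxyl-bearing chain therefore gives no sign of a step beyond the scatter, and the change in compound 4 is expected to behave alike, with a 1.0-fold higher number from compound 1 to compound 4 (0.00 log units; within the scatter) amounting to no step beyond the scatter. Compound 4 is thus estimated at 100000 nM in this assay, within 50000 nM to 200000 nM, and the result may well be reported only as a limit, as it was for compound 2.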

Compound 4, concentration for total growth inhibition: > 100000 nM
Compound 4 was reported as a limit; the forecaster's own chance of this, stated with the estimate: 50%; the middle value lies on the limit itself.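

In this assay, phenyl in place of 5-hydroxypentyl on a nitrogen on an aromatic ring gives a number no lower from compound 1 to compound 4 (the limit leaves the size open). Compound 4 gives > 100000 nM, which is a limit of the assay and not a number, and the size of this step cannot be read because the readings stop there: the limit of > 100000 nM in this assay, at which 2 of the 4 values shown sit. Phenyl now stands directly on that nitrogen, with no chain, yet compound 4 is reported as a limit just as compound 2 is, so neither phenyl compound shows a number lower than that of compound 1.

From the compounds shown here alone, how far compound 2 and compound 4 lie past the limit, and whether they differ from each other, stays open. Also open, going by these compounds, is whether an amine or a carboxylic acid in place of the phenyl would bring a lower, readable number in this assay.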